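The source may report more compounds than this note shows. Statements on the series, on what has been measured and on what is new or still open speak of the compounds shown alone.

Compound 3 `CN(Cc1ccccc1)CC1CCN(CCCc2c[nH]c3ccc(-n4cnnc4)cc23)CC1` stands second highest of the three measured compounds in a functional assay on CHO cells for activation of 5-hydroxytryptamine receptor 1D (Homo sapiens), read by GTPgammaS binding (a higher number here means a larger maximal response, a lower number a smaller maximal response), where compound 3 gives 93%. Compound 1 `CC(=O)Nc1ccc([C@H](C)NCC2CCN(CCCc3c[nH]c4ccc(-n5cnnc5)cc34)CC2)cc1` gives 99%, which lies within the scatter of compound 3. Compound 2 `c1cc(CNC2CCN(CCCc3c[nH]c4ccc(-n5cnnc5)cc34)CC2)co1` gives 65%, the lowest of the three. Compound 4 `c1ccc2c(c1)CCC2NCC1CCN(CCCc2c[nH]c3ccc(-n4cnnc4)cc23)CC1` differs from compound 3 by (2,3-dihydro-1H-inden-1-yl)amino in place of benzyl(methyl)amino on a saturated chain carbon bound to a saturated ring carbon. Among the compounds with values here, the one measured step that bears on this change, a number 28 percentage points higher from compound 2 to compound 3 (beyond the scatter), altered the amine at the same position. Compound 4 returns to an amine with a hydrogen-bond donor, as in compound 2, yet keeps a six-membered aromatic ring, as in compound 3; compound 1 combines the same two features and gives 99%. Compound 4 is therefore expected to show a step of a number 1 percentage points lower from compound 3 to compound 4 (within the scatter), within the scatter. Compound 4 is estimated at 92%, between 75% and 102%.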

Compound 4, largest response reached (reported as efficacy), in percent of the reference or control that the assay uses: 78%
Compound 4: middle estimate off by 14 percentage points, on the high side, within the range that was stated.
By their numbers in this assay, from the lowest: compound 2; then compound 4; then compounds 3 and 1 (each within the scatter of the next).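

In this assay a hydrogen-bond donor on this amine, joined to a six-membered aromatic ring, does not guarantee a full response: there is a number 15 percentage points lower from compound 3 to compound 4 (beyond the scatter) and also a number 21 percentage points lower from compound 1 to compound 4 (beyond the scatter). The furan amine still ranks lower, with a number 13 percentage points higher from compound 2 to compound 4 (beyond the scatter), so the maximal response at this position takes intermediate levels and not just high or low. Nothing measured here explains these differences. Still open, going by these compounds, is whether the lower number of compound 4 goes with the amine hydrogen or with the five-membered non-aromatic ring. A plain benzylamino group at this place would separate the two.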